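Fluoro to ethyl in a cytotoxic aryl series

The compounds below may be only part of what the source reports. "The series", "measured", "known", "first", "only" and "open" are said of these compounds alone.

Values in a functional assay on A549 cells (Homo sapiens) for cytotoxicity; a higher number here means that more compound is needed for the effect, a lower number that less compound is needed:
- compound 1 `COC1=C(C)C(=O)/C(=C(O)/C=C/c2ccc(Br)cc2)C(=O)C1(C)C`: 1.4 ug/mL
- compound 2 `COC1=C(C)C(=O)/C(=C(O)/C=C/c2ccc(OC)cc2)C(=O)C1(C)C`: 3 ug/mL
- compound 3 `COC1=C(C)C(=O)/C(=C(O)/C=C/c2ccc(F)cc2)C(=O)C1(C)C`: 3.3 ug/mL

Compound 3 stands at 3.3 ug/mL. Two measured steps place it: a 1.1-fold higher number from compound 2 to compound 3 (0.04 log units; within the scatter), and a 2.4-fold higher number from compound 1 to compound 3 (0.37 log units; beyond the scatter).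

The next entry is compound 4 `CCc1ccc(/C=C/C(O)=C2/C(=O)C(C)=C(OC)C(C)(C)C2=O)cc1`, which carries the change ethyl in place of fluoro on an aromatic carbon. All three measured steps concern this same place on the ring. The other step away from bromo, a 2.1-fold higher number from compound 1 to compound 2 (0.33 log units; beyond the scatter), is also modest, and swapping methoxy for fluoro left the number within the scatter. Going by the values given here, no ethyl compound has been measured, so these steps bound the likely size but do not fix a direction. No step beyond the scatter is expected in this assay. The expected step is a 1.3-fold lower number from compound 3 to compound 4 (0.12 log units; within the scatter). For compound 4 the estimated value is 2.5 ug/mL, with an expected range from 1.1 ug/mL to 5.5 ug/mL.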

Compound 4, concentration for half-maximal effect: 6.1 ug/mL
Estimate against measurement, compound 4: 2.4-fold (0.39 log units) below; measured number outside the range, above it.
By their numbers in this assay, from the lowest: compound 1; then compounds 2, 3 and 4 (each within the scatter of the next, the first and the last beyond it).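

In this assay, going by these compounds alone, ethyl at this place on the ring stays level with fluoro (a 1.8-fold higher number from compound 3 to compound 4 (0.27 log units; within the scatter)), yet it is the first group to separate from methoxy (a 2.0-fold higher number from compound 2 to compound 4 (0.31 log units; beyond the scatter)), a separation that fluoro did not show. Within the data shown here, the step from bromo also becomes the widest seen at this position (a 4.4-fold higher number from compound 1 to compound 4 (0.64 log units; beyond the scatter)), leaving bromo with the lowest number of the four compounds and showing that the position can carry a spread larger than the earlier steps revealed. No supporting data are available to explain this spread.

As far as these compounds go, whether the advantage of bromo extends to chloro or iodo remains open. A longer chain such as propyl, or an amine at the same place, would test whether the gap to bromo grows further than it does with ethyl.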